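A 4-hydroxyphenyl swap at the assay limit

This account rests on a few compounds, and the source may have more. Where it says the series, first, only, none or still open, it means among the compounds named here.

In a physicochemical assay for solubility (a lower number here means a less soluble compound, a higher number a more soluble compound), compound 1 `Nc1ccccc1NC(=O)c1ccc(CNC2=N[C@@H](Cc3ccccc3)CO2)cc1` gives >= 148 ug/mL, which is a limit of the assay and not a number. Compound 2 `Nc1ccccc1NC(=O)c1ccc(CNC2=NC(c3cccc(F)c3)CO2)cc1` likewise gives only a limit, >= 131 ug/mL. Compound 3 `Nc1ccccc1NC(=O)c1ccc(CNC2=N[C@@H](c3ccc(O)cc3)CO2)cc1` carries 4-hydroxyphenyl in place of benzyl on a saturated ring carbon. Within the data shown here, no measured pair shows such a change, so the expectation rests only on the limit of compound 1, >= 148 ug/mL. No shift beyond the usual scatter is expected, and the expected step is an at least 1.0-fold lower number from compound 1 to compound 3 (0.02 log units; that floor lies within the scatter). Compound 3 is estimated at 140 ug/mL, with an expected range from 60 ug/mL to 220 ug/mL.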

Compound 3, solubility: >= 130 ug/mL
Compound 3 ended at the assay's limit; the forecaster's own chance of this, stated with the estimate: 60%; the middle value does not contradict the limit.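

Among these compounds, compound 1 and compound 3 both give only a limit in this assay, so no step between them can be read. The compounds shown leave open whether 4-hydroxyphenyl in place of benzyl on a saturated ring carbon shifts this read-out at all.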